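Methyl in place of fluoro on compound 1

The compounds below may be only part of what the source reports. "The series", "measured", "known", "first", "only" and "open" are said of these compounds alone.

In a functional assay on SGC-7901 cells (Homo sapiens) for inhibition, read by MTT assay, with a stated time of 72 h (on this read-out higher numbers stand for weaker inhibition and lower numbers for stronger inhibition), compound 1 (`O=C(NCc1ccc(NC(=O)c2cccc(F)c2N2CCCC2)cc1)OCc1cccnc1`) gives > 100000 nM as a limit and not a number. Among the compounds with values here, compound 2 (`COc1ccc(N2CCCC2)c(C(=O)Nc2ccc(CNC(=O)OCc3cccnc3)cc2)c1`) gives 47200 nM in this assay and is the only measured number so far. Compound 3 (`Cc1cccc(C(=O)Nc2ccc(CNC(=O)OCc3cccnc3)cc2)c1N1CCCC1`) has methyl in place of fluoro on an aromatic carbon, ortho to a pyrrolidin-1-yl group (methyl in place of fluoro on an aromatic carbon) and is otherwise the same as compound 1. Within the data shown here, no measured step bears on this change. Among the measured compounds shown here, a small step towards stronger inhibition in this assay is expected, or none beyond the scatter, with compound 2 at 47200 nM as the only guide to where a number might fall. The expected size is an at least 1.4-fold lower number from compound 1 to compound 3 (0.15 log units; that floor lies within the scatter) at this stage. Compound 3 is estimated at 70000 nM within an expected range of 25000 nM to 150000 nM on this read-out.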

Compound 3, half-maximal inhibitory concentration: > 100000 nM
Compound 3 gave a limit, no number; the forecaster's own chance of this, stated with the estimate: 45%; middle value at least 1.4-fold (0.15 log units) from the limit.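

No step can be read from compound 1 to compound 3 in this assay, because both results are limits and not numbers: the limit of > 100000 nM in this assay, at which 2 of the 3 values shown sit.

As far as these compounds go, whether methyl in place of fluoro on an aromatic carbon changes inhibition in this assay at all, and in which direction, stays open.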